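A few compounds are considered here, and "the series" means these few. Any claim that something is new, unique, unknown or untested is made for them only; others in the source may bear on it.

In an assay on CHO cells for displacement of a labelled ligand from Glucagon receptor (Homo sapiens), read by scintillation counting, with a stated time of 60 min (a higher number here means a weaker inhibitor, a lower number a stronger inhibitor), compound 3 `CC(C)(C)CC[C@H](c1ccc(C(=O)NCc2nn[nH]n2)cc1)N1C(=O)C(c2ccc(F)cc2)=N[C@]12CC[C@@H](C(C)(C)C)CC2` gives 13 nM, the lowest of the three numbers, although compound 2 `CCCCC[C@H](c1ccc(C(=O)NCc2nn[nH]n2)cc1)N1C(=O)C(c2cc(Cl)cc(Cl)c2)=N[C@]12CC[C@@H](C(C)(C)C)CC2`, at 24 nM, lies within the scatter of it. Among the measured compounds shown here, compound 1 `CC(C)(C)CC[C@H](c1ccc(C(=O)NCc2nn[nH]n2)cc1)N1C(=O)C(c2cncc(Cl)c2)=N[C@]12CC[C@@H](C(C)(C)C)CC2` gives 38 nM, and the step of a 2.9-fold lower number from compound 1 to compound 3 (0.47 log units; beyond the scatter) is the only measured change at this carbon. Compound 4 `CC(C)(C)CC[C@H](c1ccc(C(=O)NCc2nn[nH]n2)cc1)N1C(=O)C(c2cnccc2C(F)(F)F)=N[C@]12CC[C@@H](C(C)(C)C)CC2` carries 4-(trifluoromethyl)pyridin-3-yl in place of 4-fluorophenyl on a carbon with a double bond to nitrogen. For the measured compounds named here, this brings a pyridinyl ring back to that carbon, now bearing a trifluoromethyl group rather than chlorine; the measured step ran the other way, from pyridinyl to phenyl, so a modest rise in this assay is expected for compound 4, though no measured pair isolates the trifluoromethyl group. The expected step is a 2.3-fold higher number from compound 3 to compound 4 (0.36 log units; beyond the scatter). Compound 4 is therefore estimated at 30 nM, within a range of 12 nM to 80 nM.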

Compound 4, half-maximal inhibitory concentration: 22 nM
Beside the measured number, compound 4's estimate is 1.4-fold (0.13 log units) above it, and the stated range covers the measured number.
By their numbers in this assay, from the lowest: compounds 3, 4, 2 and 1 (each within the scatter of the next, the first and the last beyond it).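

In this assay, the step of a 1.7-fold higher number from compound 3 to compound 4 (0.23 log units; within the scatter) and the step of a 1.7-fold lower number from compound 1 to compound 4 (0.24 log units; within the scatter) both stay within the scatter, so compound 4 cannot be separated from either compound, though those two are separated from each other. Of the two pyridinyl rings on this carbon, only the 5-chloropyridin-3-yl of compound 1 stands beyond the scatter from the 4-fluorophenyl of compound 3. No measurement at hand explains these steps. The compounds shown leave open what an unsubstituted pyridin-3-yl or a methyl in place of trifluoromethyl would give here. Among the compounds shown here, no pair isolates the trifluoromethyl group or the ring nitrogen.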